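Acetyl capping of the phenol in nitrothiazole salicylamides

The compounds below may be only part of what the source reports. "The series", "measured", "known", "first", "only" and "open" are said of these compounds alone.

Measured compounds:
compound 1 `O=C(Nc1ncc([N+](=O)[O-])s1)c1cc(Cl)ccc1O` — 100%
compound 2 `CC(=O)Oc1ccc(Cl)cc1C(=O)Nc1ncc([N+](=O)[O-])s1` — 59.5%
compound 3 `O=C(Nc1ncc([N+](=O)[O-])s1)c1cc(Cl)cc(Cl)c1O` — 100%

Among the compounds with values here, in an ADME assay on HEK-293T cells (Homo sapiens) for cytotoxicity, read by MTT assay, tested at 25 uM (on this read-out lower numbers stand for a stronger effect and higher numbers for a weaker effect at the one concentration tested), compound 3 gives 100%, level with compound 1, and the two free phenols share the highest reading of the series; compound 2, the only acetylated member measured, gives 59.5%. The step of no change at the digits printed from compound 1 to compound 3 (within the scatter) shows that the second chloro on the aromatic carbon leaves the read-out unchanged, so the shared core tolerates that substitution without any shift in this assay.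

Compound 4 `CC(=O)Oc1c(Cl)cc(Cl)cc1C(=O)Nc1ncc([N+](=O)[O-])s1` is the not yet measured counterpart of compound 3. Its difference from compound 3 is acetyl in place of hydrogen on an oxygen on an aromatic ring. Within the data shown here, the same change has been followed once, in the step of a number 40.5 percentage points lower from compound 1 to compound 2 (beyond the scatter), and it is the only change that moved the read-out beyond the scatter. With compound 3 starting from the same level as compound 1, the acetyl step is expected to repeat that fall, as a number 40 percentage points lower from compound 3 to compound 4 (beyond the scatter). The estimate for compound 4 is therefore 60%, within the range 40% to 85%.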

Compound 4, a percentage reported as activity, at one concentration (the size of the read-out at that concentration, not a potency): 100%
For compound 4 the middle estimate is 40 percentage points below the measured one; measured number above the stated range.
By their numbers in this assay, from the lowest: compound 2; then compounds 1, 3 and 4 (each within the scatter of the next).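

In this assay, acetyl in place of hydrogen on an oxygen on an aromatic ring gives no change at the digits printed from compound 3 to compound 4 (within the scatter), so the fall seen on the core of compound 1 does not carry over to the core of compound 3: the same change on two cores in this assay, a number 40.5 percentage points lower (beyond the scatter) from compound 1 to compound 2 and no change at the digits printed (within the scatter) from compound 3 to compound 4, 40.5 percentage points apart, beyond the scatter of two such steps. Chloro in place of hydrogen on an aromatic carbon, silent between the free phenols, gives a number 40.5 percentage points higher from compound 2 to compound 4 (beyond the scatter) once that oxygen carries acetyl: the same change on two cores in this assay, no change at the digits printed (within the scatter) from compound 1 to compound 3 and a number 40.5 percentage points higher (beyond the scatter) from compound 2 to compound 4, 40.5 percentage points apart, beyond the scatter of two such steps. The two changes therefore do not add up independently in this assay, and among these four compounds only compound 2, with the acetyl but without the added chloro, stands apart.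

As far as these compounds go, whether that low reading belongs to acetyl itself or to any cap on the oxygen remains open, and a methyl ether or a propionyl ester on both cores would separate the two. Equally open, from the compounds shown here alone, is whether the added chloro acts as a halogen specifically, which bromo or methyl in its place on compound 2 would address.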